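The source may hold more compounds than are shown below. What is called first, only, known or untested is meant among the compounds shown, and "the series" means these compounds.

Compound 1 `CN(C)c1ccc(C2CC(c3ccccc3)=NN2C2=NC(=O)/C(=C3\C(=O)Nc4ccc(Br)cc43)S2)cc1` and compound 2 `CN(C)c1ccc(C2CC(c3ccccc3)=NN2C2=NC(=O)/C(=C3\C(=O)Nc4ccc(Cl)cc43)S2)cc1` share one core, while compound 3 `COc1ccc(-c2cc(-c3ccc(Cl)cc3)n(C3C(=O)Nc4ccc(Br)cc43)n2)cc1` is built on another; the difference between the two cores is not broken down here. In a functional assay on cells (Cancer cell lines, Homo sapiens) for cytotoxicity, read by sulforhodamine B assay, with a stated time of 48 h (on this read-out higher numbers stand for weaker inhibition of growth and lower numbers for stronger inhibition of growth), compound 1 gives 250 nM, and compound 2 gives 240 nM. Within the data shown here, the only change between them is chloro in place of bromo on an aromatic carbon, and that change made a step of a 1.0-fold lower number from compound 1 to compound 2 (0.02 log units; within the scatter). Compound 3 gives 9750 nM in this assay, a far higher number than either of the other two.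

Compound 4 `COc1ccc(-c2cc(-c3ccc(Cl)cc3)n(C3C(=O)Nc4ccc(Cl)cc43)n2)cc1` is the not yet measured partner of compound 3, and it differs from compound 3 by chloro in place of bromo on an aromatic carbon. Among the measured compounds shown here, this is the same change as the one from compound 1 to compound 2, at a place described in the same words. Because the step of a 1.0-fold lower number from compound 1 to compound 2 (0.02 log units; within the scatter) was within the scatter, the expectation is that the step from compound 3 to compound 4 will also be small, about a 1.0-fold lower number from compound 3 to compound 4 (0.01 log units; within the scatter). On that basis compound 4 is expected to give about 9500 nM in this assay, estimated to fall between 4500 nM and 20000 nM.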

Compound 4, concentration for 50% growth inhibition: 3680 nM
For compound 4 the middle estimate is 2.6-fold (0.41 log units) above the measured one; measured number outside the range, below it.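

In this assay, chloro in place of bromo on the aromatic carbon gives a 2.6-fold lower number from compound 3 to compound 4 (0.42 log units; beyond the scatter), a modest step that, taken alone, is larger than the usual scatter of repeated measurements. Set beside the earlier pair, this step cannot be told apart from the one on the other core, so the data show no sign that the swap behaves differently on the two cores: the same change on two cores in this assay, a 1.0-fold lower number (0.02 log units; within the scatter) from compound 1 to compound 2 and a 2.6-fold lower number (0.42 log units; beyond the scatter) from compound 3 to compound 4, 2.5-fold (0.41 log units) apart, within the scatter of two such steps. This is only a lack of a detectable difference, and two pairs in a single assay do not prove that the step has a fixed size or predict its size on a further core.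

The compounds shown leave open how a fluoro group, a nitrile or an amine would compare with bromo and chloro on this same aromatic carbon of either core. They also leave open whether the two steps would stay alike in any other kind of test.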